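The compounds below may be only part of what the source reports. "The series", "measured", "known", "first", "only" and "open" are said of these compounds alone.

Of the compounds shown here, two from this series have so far been tested in an ADME assay on MRC5 cells (Homo sapiens) for inhibition, with a stated time of 72 h; on this read-out higher numbers stand for an effect only at larger amounts of compound and lower numbers for an effect already at smaller amounts. Among the measured compounds shown here, compound 1 `COc1cccc(OC)c1C(=O)Nc1c[nH]nc1C(=O)N[C@H]1CC[C@H](O)CC1` gives 34000 nM, and it is the only compound for which a number rather than a limit was obtained. Compound 2 `CO[C@H]1CC[C@H](NC(=O)c2n[nH]cc2NC(=O)C2CCC(F)(F)CC2)CC1` returns > 50000 nM, which is a limit of the assay and not a number. For the measured compounds named here, compound 1 therefore stands as the sole real value, while the other result sits at the limit of > 50000 nM in this assay, at which 1 of the 2 values shown sits. Going by the values given here, no two measured compounds differ in just one place, so no step within the data can be sized.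

Compound 3 `COC(=O)c1n[nH]cc1NC(=O)c1c(OC)cccc1OC` is the next compound to consider. It differs from compound 1 in a single change, (methoxy in place of (4-hydroxycyclohexyl)amino on a carbonyl carbon). Among the compounds with values here, with no measured step to lean on, the expectation rests only on compound 1, which gives 34000 nM. From compound 1, the step of a 1.1-fold lower number from compound 1 to compound 3 (0.05 log units; within the scatter) is expected to be small, within or close to the usual scatter, in either direction. Compound 3 is thus expected to give about 30000 nM, with a likely range from 10000 nM to 80000 nM.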

Compound 3, half-maximal effective concentration: > 50000 nM
Compound 3 ended at the assay's limit; the forecaster's own chance of this, stated with the estimate: 40%; at least 1.6-fold (0.22 log units) between middle value and limit.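

Among the compounds shown here, putting methoxy in place of (4-hydroxycyclohexyl)amino on a carbonyl carbon gives the first step that can be read at this position in this assay, and it is an at least 1.4-fold higher number from compound 1 to compound 3 (0.16 log units; that floor lies within the scatter). The change removes the six-membered ring, its two defined stereocentres and both hydrogen-bond donors of the leaving group, yet the number does not come down, so the (4-hydroxycyclohexyl)amino group is not needed for the effect to stay this weak on these cells. The result for compound 3 is a limit of the assay and not a number, and compound 3 now shares it with another member of the series: the limit of > 50000 nM in this assay, at which 2 of the 3 values shown sit.

On these data alone, how far compound 3 really lies from compound 1 stays unknown, since only a floor is printed and that floor does not clear the scatter. Also open, as far as these compounds go, is whether a small amine such as methylamino, or a longer chain such as an ethoxy group, on this carbonyl carbon would give a number rather than a limit, which would show how much this position can shift the read-out at all.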